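The compounds below may be only part of what the source reports. "The series", "measured", "known", "first", "only" and "open" are said of these compounds alone.

Measured so far:
- compound 1, `O=C(Nc1ccc(F)c(C(F)(F)F)c1)Nc1cnccn1`: 160 uL/min
- compound 2, `O=C(Nc1ccnc(C(F)(F)F)c1)Nc1ccc(F)c(C(F)(F)F)c1`: < 7 uL/min

Two compounds have been run through an ADME assay on microsomes from liver (Mus musculus) for metabolic stability, using NADPH, with a stated time of 60 min; on this read-out lower numbers stand for slow clearance and higher numbers for fast clearance. Compound 1, whose structure is `O=C(Nc1ccc(F)c(C(F)(F)F)c1)Nc1cnccn1`, gives 160 uL/min in this assay. Compound 2, whose structure is `O=C(Nc1ccnc(C(F)(F)F)c1)Nc1ccc(F)c(C(F)(F)F)c1`, gives < 7 uL/min, and that value is a limit of the assay rather than a number. Compound 1 therefore stands as the only numerical result so far; the other entry is the limit of < 7 uL/min in this assay, at which 1 of the 2 values shown sits.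

Compound 3, whose structure is `O=C(Nc1ccc(F)c(C(F)(F)F)c1)Nc1ccccn1`, has not yet been measured. It differs from compound 1 in one place: pyridin-2-yl in place of pyrazin-2-yl on an amide-type nitrogen. Within the data shown here, no measured pair in this set shows that change, so its effect on clearance is not known from the data at hand. The expectation is a step toward faster clearance, of a size at or just beyond the usual scatter of this assay. The step that this estimate means, a 1.5-fold higher number from compound 1 to compound 3 (0.18 log units; within the scatter), is an expectation only. Compound 3 is accordingly estimated to give about 240 uL/min in this assay, with a range from 100 uL/min to 550 uL/min.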

Compound 3, intrinsic clearance in a liver preparation (reported as CLH), per the amount of preparation that the assay uses: 705 uL/min
The estimate for compound 3 lay 2.9-fold (0.47 log units) below the measured number, and the stated range ends below it.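

Placing pyridin-2-yl in place of pyrazin-2-yl on the amide-type nitrogen produces a 4.4-fold higher number from compound 1 to compound 3 (0.64 log units; beyond the scatter) in this assay. This is the first pair shown that isolates this position, and it shows that clearance here responds to a small edit: the two rings are the same size, and a ring nitrogen of pyrazin-2-yl is simply a carbon in pyridin-2-yl, yet the step lies beyond the usual scatter of repeated measurements. Compound 2 gives a limit of the assay and not a number, so no step involving it can be read: the limit of < 7 uL/min in this assay, at which 1 of the 3 values shown sits.

A single pair cannot say whether this swap would give a step of similar size on a different core, or whether the rest of the molecule influences it. Also open, from the compounds shown here alone, is how clearance would respond at this place to a pyrimidin-2-yl or thiazol-2-yl ring, to a plain phenyl ring, or to pyridin-2-yl carrying an added amine or carboxylic acid.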